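A few compounds are considered here, and "the series" means these few. Any claim that something is new, unique, unknown or untested is made for them only; others in the source may bear on it.

Measured so far:
compound 1, `O=C(CCCCCCc1ccccc1)c1nc(Br)co1`: > 10000 nM
compound 2, `CNC(=O)c1coc(C(=O)CCCCCCc2ccccc2)n1`: > 10000 nM

Both values are limits of an assay on HEK-293T cells for inhibition of diacylglycerol lipase-alpha (Homo sapiens), read by colorimetric assay (a higher number here means a weaker inhibitor, a lower number a stronger inhibitor), not numbers. In this assay compound 1 gives > 10000 nM, which is a limit. Compound 2 gives > 10000 nM, also a limit. For the measured compounds named here, both sit at the limit of > 10000 nM in this assay, at which 2 of the 2 values shown sit, so compound 1 cannot be ranked against compound 2, and the only measured step, a step that the two limits leave unreadable from compound 1 to compound 2, has no readable size. Compound 1 therefore stands at the limit, with nothing measured above or below it.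

Compound 3, `O=C(CCCCCCc1ccccc1)c1ncc(Cl)o1`, keeps the shared core and the seven-carbon chain ending in a phenyl and differs from compound 1 only in 5-chloro-1,3-oxazol-2-yl in place of 4-bromo-1,3-oxazol-2-yl on a carbonyl carbon. Going by the values given here, no measured step concerns this change, and the one step that exists could not be read, so no size can be taken from it. With both measured compounds at the limit, compound 3 is expected to stay there too: its estimate in this assay is 15000 nM, with a range from 3000 nM to 60000 nM. The step that the limit leaves unreadable from compound 1 to compound 3 is expected to be no larger than the usual scatter.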

Compound 3, half-maximal inhibitory concentration: > 10000 nM
Compound 3: no number, only a limit (the forecaster's own chance of this, stated with the estimate: 75%); the middle value lies beyond the limit too.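

In this assay compound 3 gives > 10000 nM and this is a limit, not a number. For the compounds shown here, no step among compound 1, compound 2 and compound 3 can be read, and all three stand together: the limit of > 10000 nM in this assay, at which 3 of the 3 values shown sit. The compounds shown leave open how strongly any of them inhibits the enzyme, and which change to them would give a readable number.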